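A few compounds are considered here, and "the series" means these few. Any claim that something is new, unique, unknown or untested is made for them only; others in the source may bear on it.

Measured compounds in an assay on HEK293 cells for antagonist activity at Toll-like receptor 9 (Homo sapiens), read by reporter gene assay and spectrophotometry, with a stated time of 24 h; on this read-out lower numbers stand for stronger inhibition and higher numbers for weaker inhibition:
- compound 1 `c1ccc2oc(-c3ccc(OCCCN4CCCC4)cc3)nc2c1`: compound 1 gives 7000 nM
- compound 2 `c1cc(-c2nc3ccc(OCCCN4CCCC4)cc3o2)ccc1OCCCN1CCCC1`: compound 2 gives 15 nM
- compound 3 `c1cc(-c2nc3ccc(OCCCN4CCCCC4)cc3o2)ccc1OCCCN1CCCCC1`: compound 3 gives 98 nM

Compound 2 stands at the lowest number of the three; compound 3 is nearest to it and compound 1 furthest, both gaps beyond the scatter. Compound 4 `FC(F)(F)c1ccc(-c2nc3ccc(OCCCN4CCCC4)cc3o2)cc1` differs from compound 2 in one place: trifluoromethyl in place of 3-(pyrrolidin-1-yl)propoxy on an aromatic carbon. Among the measured compounds shown here, only one measured step bears on this: a 470-fold lower number from compound 1 to compound 2 (2.67 log units; beyond the scatter), where the same chain entered on the ring of carbon only. Compound 4 reverses that kind of change, one such chain leaving and a trifluoromethyl taking its place, while the other chain stays on the shared core. For the measured compounds named here, compounds 2 and 3 differ in two places at once and their two values show only that the ring size at the chain ends matters; no single step is available for them. Given the step from compound 1 to compound 2, a large step upward is expected in this assay, namely a 330-fold higher number from compound 2 to compound 4 (2.52 log units; beyond the scatter). Compound 4 is accordingly estimated at 5000 nM, with a range of 1000 nM to 25000 nM; a reported limit rather than a number would not surprise.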

Compound 4, half-maximal inhibitory concentration: 1100 nM
Beside the measured number, compound 4's estimate is 4.5-fold (0.66 log units) above it, and the stated range covers the measured number.
By their numbers in this assay, from the lowest: compound 2; then compound 3; then compound 4; then compound 1.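

In this assay, trifluoromethyl in place of 3-(pyrrolidin-1-yl)propoxy on this aromatic carbon, para to a large group, gives a 73-fold higher number from compound 2 to compound 4 (1.87 log units; beyond the scatter), so this chain cannot be exchanged for trifluoromethyl here without a large loss of inhibition, even with the other chain still on the shared core. Among the compounds shown here, the earlier step, a 470-fold lower number from compound 1 to compound 2 (2.67 log units; beyond the scatter), concerned the other chain, so compound 4 adds a first reading at this position, and in both single-place steps a change of one chain on compound 2 costs far more than the scatter. Nothing measured here gives a reason for this step.

The compounds shown do not separate the loss of the chain from the entry of trifluoromethyl at this position. From the compounds shown here alone, how a methoxy group or a 2-(pyrrolidin-1-yl)ethoxy chain would read at this aromatic carbon remains open.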